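Chloro to Nitro on a Fused Core in Cytotoxicity

This account rests on a few compounds, and the source may have more. Where it says the series, first, only, none or still open, it means among the compounds named here.

Compound 1 `O=C(Cn1c(=O)oc2cc(Cl)ccc21)Nc1ccccc1` and compound 2 `O=C(Cn1c(=O)oc2cc([N+](=O)[O-])ccc21)Nc1ccccc1` share one core and differ by nitro in place of chloro on an aromatic carbon. In an ADME assay on RAW264.7 cells (Mus musculus) for cytotoxicity, read by MTT assay, with a stated time of 72 h, tested at 50 uM (a lower number here means a weaker effect, a higher number a stronger effect of the compound at the concentration tested), compound 1 gives 15.8%. In this assay compound 2 gives 18%. That step is a number 2.2 percentage points higher from compound 1 to compound 2 (within the scatter). Compound 3 `O=C(Cn1c(=O)oc2cc(Cl)ccc21)Nc1nc2ccc([N+](=O)[O-])cc2s1` carries another amide partner; the difference between its core and that of compound 1 is not broken down here. In this assay compound 3 gives 12.5%. Compound 4 `O=C(Cn1c(=O)oc2cc([N+](=O)[O-])ccc21)Nc1nc2ccc([N+](=O)[O-])cc2s1` arises from compound 3 by the same change, (nitro in place of chloro on an aromatic carbon). Because the matching step a number 2.2 percentage points higher from compound 1 to compound 2 (within the scatter) stayed within the scatter, compound 4 is expected to move by only a number 2.5 percentage points higher from compound 3 to compound 4 (within the scatter). In this assay compound 4 is therefore estimated at 15%, expected to fall between 6% and 26%.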

Compound 4, a percentage reported as inhibition, at one concentration (the size of the read-out at that concentration, not a potency): 14.8%
For compound 4 the middle estimate is 0.2 percentage points above the measured one; low and high end bracket the measured number.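

In this assay, nitro in place of chloro on an aromatic carbon of the second core comes to a number 2.3 percentage points higher from compound 3 to compound 4 (within the scatter). The change carries from one core to the other with the same small size: the same change on two cores in this assay, a number 2.2 percentage points higher (within the scatter) from compound 1 to compound 2 and a number 2.3 percentage points higher (within the scatter) from compound 3 to compound 4, 0.1 percentage points apart, within the scatter of two such steps This shows that the two steps agree, yet neither lies beyond the scatter, so it shows only that the read-out hardly responds to this change on these two cores at one tested concentration, and it shows nothing about potency or about other cores.

The compounds shown leave open how an amine or a carboxylic acid on that aromatic carbon would read in this assay. They also leave open whether an amide partner with a longer chain would keep the read-out in this range.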